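The source may hold more compounds than are shown below. What is called first, only, known or untested is meant among the compounds shown, and "the series" means these compounds.

Working notes on the series. Compound 1 `C=C(C)c1cccc(N2CCN(C(=O)c3oc(C)nc3-c3ccccc3F)CC2)c1` is the starting point; in a functional assay on HL-60 cells (Homo sapiens) for inhibition, read by MTT assay, with a stated time of 72 h (on this read-out lower numbers stand for stronger inhibition and higher numbers for weaker inhibition), compound 1 gives "not active" (no number reported), so no single number stands for it. Compound 3 `COc1cccc(N2CCN(C(=O)c3oc(C(F)(F)F)nc3-c3cccc(F)c3)CC2)c1` is in the same position: in this assay compound 3 gives "not active" (no number reported). Compound 2 `CCc1nc(-c2ccc(OC)cc2)c(C(=O)N2CCN(c3cccc(Cl)c3)CC2)o1` is the only one with a reported figure, and in this assay compound 2 gives > 1000 nM, which is a limit of the assay and not a number. Taken together, (the limit of > 1000 nM in this assay, at which 1 of the 3 values shown sits), and the other two entries carry no number at all. Compound 1 therefore stands nowhere on a scale: it sits among entries that are either a limit or no number.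

Compound 4 `Cc1nc(-c2ccccc2F)c(C(=O)N2CCN(c3cc(Cl)cc(Cl)c3)CC2)o1` has not been measured. Relative to compound 1 the change is 3,5-dichlorophenyl in place of 3-(1-methylethenyl)phenyl on an amine nitrogen in a ring. Among the measured compounds shown here, no step between measured compounds exists, so there is nothing on which to size the change; with compound 1 holding no number, a step to compound 4 cannot be expected to resolve beyond the scatter in either direction. Compound 4 is expected to give about 3000 nM in this assay, within 500 nM to 20000 nM, with a substantial chance that only a limit is reported.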

Compound 4, half-maximal inhibitory concentration: 60.2 nM
Compound 4: middle estimate off by 50-fold (1.70 log units), on the high side; the measured number lies below the stated range.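

No new step can be read between compound 1 and compound 4: compound 4 carries a number, while compound 1 carries none. Whether 3,5-dichlorophenyl in place of 3-(1-methylethenyl)phenyl accounts for the activity of compound 4 stays open, and nothing shown bears on that.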